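Swapping the amide group on a carbonyl carbon

The source may report more compounds than this note shows. Statements on the series, on what has been measured and on what is new or still open speak of the compounds shown alone.

Measured in a functional assay on BXPC-3 cells (Homo sapiens) for cytotoxicity, read by fluorescence, with a stated time of 48 h; a higher number here means that more compound is needed for the effect, a lower number that less compound is needed:
- compound 1 `CC(C)=CCC/C(C)=C/CC/C(C)=C/CSC[C@H](NC(=O)CCCCCN1CCN(C)CC1)C(=O)NC1CCCCCC1`: 6200 nM
- compound 2 `CC(C)=CCC/C(C)=C/CC/C(C)=C/CSC[C@H](NC(=O)CCCCCN1CCN(C)CC1)C(=O)N1CCCC1`: 3200 nM
- compound 3 `CC(C)=CCC/C(C)=C/CC/C(C)=C/CSC[C@H](NC(=O)CCCCCN1CCCC1)C(=O)N1CCCCC1`: 8700 nM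

Compound 1 stands in the middle of these three numbers, within the usual scatter of both others. Compound 4 `CC(C)=CCC/C(C)=C/CC/C(C)=C/CSC[C@H](NC(=O)CCCCCN1CCN(C)CC1)C(=O)N1CCCCC1` places piperidin-1-yl in place of cycloheptylamino on a carbonyl carbon. Within the data shown here, the one measured step at this place, a 1.9-fold lower number from compound 1 to compound 2 (0.29 log units; within the scatter), brings in pyrrolidin-1-yl instead. Compound 3 also carries piperidin-1-yl there, but it differs from compound 4 in a second place too. The expected step, a 1.2-fold lower number from compound 1 to compound 4 (0.09 log units; within the scatter), is therefore estimated to stay within the scatter of this assay. The estimate for compound 4 is 5000 nM, with an expected range of 2500 nM to 10000 nM.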

Compound 4, half-maximal effective concentration: 8800 nM
Compound 4: the middle estimate sits 1.8-fold (0.25 log units) below what was measured, and the stated range covers the measured number.
By their numbers in this assay, from the lowest: compounds 2, 1, 3 and 4 (each within the scatter of the next, the first and the last beyond it).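

In this assay, among these compounds, piperidin-1-yl in place of cycloheptylamino on this carbonyl carbon stays within the scatter (a 1.4-fold higher number from compound 1 to compound 4 (0.15 log units; within the scatter)), while piperidin-1-yl in place of pyrrolidin-1-yl gives the first step here beyond it, though a modest one (a 2.8-fold higher number from compound 2 to compound 4 (0.44 log units; beyond the scatter)). 4-Methylpiperazin-1-yl in place of pyrrolidin-1-yl on a saturated chain carbon, five bonds along the chain from a carbonyl carbon, also stays within the scatter (a 1.0-fold higher number from compound 3 to compound 4 (0.00 log units; within the scatter)). No measurement here explains the gap between the pyrrolidin-1-yl and piperidin-1-yl compounds. Still open, as far as these compounds go, is how a morpholin-4-yl group or an open-chain diethylamino group would behave on this carbonyl carbon.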